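Swapping Chloro for Bromo on a Fused Ring

The source may report more compounds than this note shows. Statements on the series, on what has been measured and on what is new or still open speak of the compounds shown alone.

Compound 2 `FC(F)(F)c1ccccc1-c1cc(Cl)c2[nH]c(C3=NOC4(CCCCC4)C3)nc2c1` gives 3.3 nM in a functional assay on HEK293 cells for antagonist activity at transient receptor potential M8 protein (Canis lupus familiaris), read by FLIPR and calcium flux; on this read-out higher numbers stand for weaker inhibition and lower numbers for stronger inhibition. On the numbers at hand this is the higher of two, yet compound 1 `FC(F)(F)c1ccccc1-c1ccc2[nH]c(C3=NOC4(CCCCC4)C3)nc2c1` gives 3.1 nM, and the two results sit within the scatter of each other. Among the measured compounds shown here, the only measured step, a 1.1-fold higher number from compound 1 to compound 2 (0.03 log units; within the scatter), shows that adding a chlorine at that aromatic carbon of the shared core did not shift the read-out beyond the scatter.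

Compound 3 `FC(F)(F)c1ccccc1-c1cc(Br)c2[nH]c(C3=NOC4(CCCCC4)C3)nc2c1` is the next variation: bromo in place of chloro on an aromatic carbon. For the measured compounds named here, no measured step covers an exchange of one halogen for another, so the single step bears on this case only indirectly, in that a change at this same carbon left the number essentially unmoved. On that basis the step of no change at the digits printed from compound 2 to compound 3 (within the scatter) is expected to stay within the scatter. Compound 3 is therefore estimated at 3.3 nM, with a likely range from 1.5 nM to 7.5 nM.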

Compound 3, half-maximal inhibitory concentration: 2.7 nM
Beside the measured number, compound 3's estimate is 1.2-fold (0.09 log units) above it; the measured number falls inside the stated range.
By their numbers in this assay, from the lowest: compounds 3, 1 and 2 (each within the scatter of the next).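

In this assay, exchanging one halogen for a larger one at this aromatic carbon gives a 1.2-fold lower number from compound 2 to compound 3 (0.09 log units; within the scatter), so the earlier finding for chloro now has a second halogen alongside it. Set against the unsubstituted compound, bromo gives a 1.1-fold lower number from compound 1 to compound 3 (0.06 log units; within the scatter), which means that hydrogen, chloro and bromo at this carbon of the shared core all read alike, with compounds 1, 2 and 3 each within the scatter of the next. Nothing measured alongside these numbers offers an explanation for this flat result.

From the compounds shown here alone, all three compounds carry only hydrogen or a single halogen here, so it remains open whether an amine, a carboxylic acid or a longer chain such as propyl at this carbon would read alike. Going by these compounds, whether bromo would behave the same way on any other aromatic carbon of the core also remains open.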